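A few compounds are considered here, and "the series" means these few. Any claim that something is new, unique, unknown or untested is made for them only; others in the source may bear on it.

Compound 1, `CN(c1ccc2cc(NC(=O)CCc3ccc(C(F)(F)F)cc3)ccc2n1)C1CCCC1`, gives 2 nM in an assay on isolated protein for displacement of a labelled ligand from melanin-concentrating hormone receptor 1 (Homo sapiens); on this read-out higher numbers stand for weaker inhibition and lower numbers for stronger inhibition. Compound 2, `O=C(CCc1ccc(C(F)(F)F)cc1)Nc1ccc2nc(N3CC4CCC3CC4)ccc2c1`, gives 3 nM in this assay.

Compound 2 and compound 1 sit within the scatter of each other: the change a 1.5-fold higher number from compound 1 to compound 2 (0.18 log units; within the scatter) is too small to separate them. Compound 3, `NC1CCN(c2ccc3cc(NC(=O)CCc4ccc(C(F)(F)F)cc4)ccc3n2)C1`, has not yet been measured. It differs from compound 2 by a group of 6 heavy atoms (4 carbon, 2 nitrogen; one five-membered non-aromatic ring with 1 hetero atom) in place of a group of 8 heavy atoms (7 carbon, 1 nitrogen; 2 six-membered non-aromatic rings with 1 hetero atom each), on an aromatic carbon. For the measured compounds named here, the one measured step that bears on this is the exchange at the same aromatic carbon of compound 1 for compound 2, where one saturated amine ring was swapped for another and the number moved a 1.5-fold higher number from compound 1 to compound 2 (0.18 log units; within the scatter), within the scatter. On that basis the swap to the 3-aminopyrrolidin-1-yl group is expected to leave the number close to where compound 2 stands, with no step beyond the scatter foreseen: the expected move is a 1.3-fold higher number from compound 2 to compound 3 (0.12 log units; within the scatter). Compound 3 is therefore estimated at 4 nM, with a range of 1.5 nM to 12 nM.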

Compound 3, half-maximal inhibitory concentration: 12 nM
Estimate against measurement, compound 3: 3.0-fold (0.48 log units) below; low and high end bracket the measured number.
By their numbers in this assay, from the lowest: compounds 1 and 2 (each within the scatter of the next); then compound 3.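

The position next to the ring nitrogen does not accept every saturated amine ring alike. The exchange between compound 1 and compound 2 gave no separable change, whereas 3-aminopyrrolidin-1-yl gives a step beyond the scatter in this assay with a 4.0-fold higher number from compound 2 to compound 3 (0.60 log units; beyond the scatter) and also with a 6.0-fold higher number from compound 1 to compound 3 (0.78 log units; beyond the scatter) as the second comparison. Both steps are modest, and they set compound 3 apart from the other two compounds, which stay within the scatter of each other. Nothing available here accounts for these steps.

The ring size and the added primary amine change together in compound 3, so the compounds shown leave open which of the two goes with the step. An unsubstituted pyrrolidin-1-yl or a 4-aminopiperidin-1-yl group would pull these two changes apart.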